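This account rests on a few compounds, and the source may have more. Where it says the series, first, only, none or still open, it means among the compounds named here.

Working notes on a short series built on one shared core and tested in an assay on isolated protein for displacement of a labelled ligand from metabotropic glutamate receptor 5 (Homo sapiens), with a stated time of 60 min, tested at 1 uM; a higher number here means more inhibition at the concentration tested (going by the name of the read-out), a lower number less inhibition. Compound 1 `CC1CCN(c2c(S(=O)(=O)c3ccc(F)cc3)cnc3ccc(F)cc23)CC1` gives 87%. Compound 2 `CC1CCN(c2c(S(=O)(=O)c3ccc(F)c(F)c3)cnc3ccc(F)cc23)CC1` carries a fluoro in place of a hydrogen on an aromatic carbon and gives 82%. The step of a number 5 percentage points lower from compound 1 to compound 2 (within the scatter) stays within the scatter. Compound 3 `CC1CCN(c2c(S(=O)(=O)c3ccccc3)cnc3ccc(F)cc23)CC1` gives 40%, the lowest of the three numbers; its nearest neighbour is compound 2 and its furthest is compound 1, both separated from it by more than the scatter.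

Compound 4 `Cc1ccc(S(=O)(=O)c2cnc3ccc(F)cc3c2N2CCC(C)CC2)cc1F` differs from compound 3 by 3-fluoro-4-methylphenyl in place of phenyl on a sulfonyl sulfur. The measured steps that bear on this change are a number 47 percentage points lower from compound 1 to compound 3 (beyond the scatter) and a number 42 percentage points lower from compound 2 to compound 3 (beyond the scatter), both large, each a fall when a fluoro-bearing ring on the sulfonyl sulfur gives way to plain phenyl. For the measured compounds named here, compound 4 restores a fluoro to that ring and adds a methyl, for which the measured compounds offer no precedent, so a rise of comparable size is expected, with the step estimated at a number 38 percentage points higher from compound 3 to compound 4 (beyond the scatter). For compound 4 in this assay the estimate is 78%, within a range from 55% to 92%.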

Compound 4, a percentage reported as inhibition, at one concentration (the size of the read-out at that concentration, not a potency): 86%
Estimate against measurement, compound 4: 8 percentage points below, and the stated range covers the measured number.
By their numbers in this assay, from the lowest: compound 3; then compounds 2, 4 and 1 (each within the scatter of the next).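

In this assay, 3-fluoro-4-methylphenyl in place of phenyl on the sulfonyl sulfur gives a number 46 percentage points higher from compound 3 to compound 4 (beyond the scatter), so a ring carrying both a fluoro and a methyl also stands clear of plain phenyl. Methyl in place of fluoro on an aromatic carbon gives a number 4 percentage points higher from compound 2 to compound 4 (within the scatter), and 3-fluoro-4-methylphenyl in place of 4-fluorophenyl gives a number 1 percentage points lower from compound 1 to compound 4 (within the scatter), so this read-out does not separate the three substituted rings. Nothing available gives a reason for the gap between these rings and plain phenyl.

Still open, as far as these compounds go, is whether 4-methylphenyl, or a ring bearing chloro or methoxy, would stay with the substituted rings or fall towards plain phenyl. A reading at a single concentration also leaves open whether compound 1, compound 2 and compound 4 would separate at any other concentration.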